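Indole-2-carboxylate triazolylmethyl esters: 2-bromophenyl variant

This account rests on a few compounds, and the source may have more. Where it says the series, first, only, none or still open, it means among the compounds named here.

Compound 1 `Cc1cccc(-n2cc(COC(=O)c3cc4ccccc4[nH]3)nn2)c1C` is the anchor of this small set. In a functional assay on MCF7 cells (Homo sapiens) for cytotoxicity, read by MTT assay, with a stated time of 48 h (a higher number here means a weaker inhibitor, a lower number a stronger inhibitor), compound 1 gives 17100 nM, the lowest of the two numbers recorded. The nearest measured number belongs to compound 3 `O=C(OCc1cn(-c2ccccc2Br)nn1)c1cc2ccccc2n1Cc1cn(-c2ccccc2Br)nn1`, which carries the 2-bromophenyl triazolylmethyl group on both the ester and the ring nitrogen of the shared core; in this assay compound 3 gives 64100 nM, a gap from compound 1 that lies beyond the usual scatter. Compound 2 `Cc1cccc(-n2cc(COC(=O)c3cc4ccccc4n3Cc3cn(-c4cccc(C)c4C)nn3)nn2)c1C`, the doubly substituted counterpart of compound 1 with 2,3-dimethylphenyl on both triazoles, reaches only a limit of the assay: in this assay compound 2 gives > 200000 nM. This is the limit noted as the limit of > 200000 nM in this assay, at which 1 of the 3 values shown sits.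

Compound 4 `O=C(OCc1cn(-c2ccccc2Br)nn1)c1cc2ccccc2[nH]1` keeps the unsubstituted ring nitrogen of compound 1 and differs from it by 2-bromophenyl in place of 2,3-dimethylphenyl on an aromatic nitrogen. Within the data shown here, no measured pair isolates this change; the doubly substituted compounds 2 and 3 only show that the 2-bromophenyl pair yields a number where the 2,3-dimethylphenyl pair yields a limit. For compound 4 the expected step of a 1.2-fold lower number from compound 1 to compound 4 (0.09 log units; within the scatter) is therefore small, not clearly beyond the scatter, with a slight lean toward a lower number. Compound 4 is estimated at 14000 nM, within 5000 nM to 45000 nM.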

Compound 4, half-maximal inhibitory concentration: 38800 nM
Estimate against measurement, compound 4: 2.8-fold (0.44 log units) below; low and high end bracket the measured number.
By their numbers in this assay, from the lowest: compound 1; then compounds 4 and 3 (each within the scatter of the next). At a limit, above all of these: compound 2.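

Among these compounds, replacing 2,3-dimethylphenyl with 2-bromophenyl on an aromatic nitrogen of the five-membered aromatic ring with 3 nitrogen gives in this assay a 2.3-fold higher number from compound 1 to compound 4 (0.36 log units; beyond the scatter) and so provides the first reading of this change with only one place altered. With the ring nitrogen of the shared core left unsubstituted, the 2,3-dimethylphenyl group holds the lower number, and the step is modest, so at this position the two aryl groups are separated, though not widely. Nothing measured here accounts for the direction or size of this step, and the assay limit recorded for compound 2 offers no explanation for it.

As far as these compounds go, two aryl groups cannot define a trend at this position, so it remains open whether the difference follows the bromine, the pair of methyl groups or the size of the group, and an unsubstituted phenyl, a 2-methylphenyl or a 2-chlorophenyl would help to separate these. Also open, from the compounds shown here alone, is whether a more distinct group here, such as a pyridine ring or an aminophenyl, would move the number further than either aryl group does.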